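Bile acid transporter inhibitors: carbamate in place of methoxy

The source may hold more compounds than are shown below. What is called first, only, known or untested is meant among the compounds shown, and "the series" means these compounds.

Three measured members of the series share one core and differ only on the aromatic ring of the fused system. Compound 1 `CCCC[C@]1(CC)CS(=O)(=O)c2ccc(Br)cc2[C@@H](c2cccc(OC)c2)[C@H]1O` carries a bromine there, compound 2 `CCCC[C@]1(CC)CS(=O)(=O)c2ccc(OC)cc2[C@@H](c2ccccc2)[C@H]1O` a methoxy, and compound 3 `CCCC[C@]1(CC)CS(=O)(=O)c2cc(O)ccc2[C@@H](c2ccccc2)[C@H]1O` a hydroxy. In an assay on cells for inhibition of ileal sodium/bile acid cotransporter (Homo sapiens) (on this read-out higher numbers stand for weaker inhibition and lower numbers for stronger inhibition), compound 1 gives 70 nM, compound 2 gives 55 nM and compound 3 gives 90 nM. The three numbers lie within the scatter of one another, so compound 2 cannot be set apart from compound 1 or compound 3 on these values; the substituents tried so far leave the read-out essentially unchanged.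

Compound 4 `CCCC[C@]1(CC)CS(=O)(=O)c2ccc(NC(=O)OCc3ccccc3)cc2[C@@H](c2ccccc2)[C@H]1O` has not been measured. It differs from compound 2 by (benzyloxycarbonyl)amino in place of methoxy on an aromatic carbon. For the measured compounds named here, no measured pair shows a change of this kind, and the three measured compounds give no trend to build on. The step from methoxy to (benzyloxycarbonyl)amino is expected to shift the read-out little, and the direction is uncertain; the estimated step of a 1.8-fold higher number from compound 2 to compound 4 (0.26 log units; within the scatter) is expected to stay within the scatter. On that basis compound 4 is expected to give about 100 nM in this assay, with a range from 35 nM to 300 nM.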

Compound 4, half-maximal inhibitory concentration: 400 nM
Compound 4: the middle estimate sits 4.0-fold (0.60 log units) below what was measured, and the stated range ends below it.
By their numbers in this assay, from the lowest: compounds 2, 1 and 3 (each within the scatter of the next); then compound 4.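

In this assay, for the compounds shown here, the aromatic carbon meta to a fused ring and para to a fused ring does respond to what it carries: (benzyloxycarbonyl)amino in place of methoxy gives a 7.3-fold higher number from compound 2 to compound 4 (0.86 log units; beyond the scatter), the only step read so far and one beyond the scatter. The earlier compounds shown here, all within the scatter of one another, gave no sign of this, and their flat picture does not extend to every substituent at this carbon. The change puts 11 heavy atoms in place of 2 and adds an aromatic ring and a hydrogen-bond donor, but no available evidence ties the step to any one of these features.

Still open is which part of the entering group accounts for the step: an unsubstituted amine or an acetamide at this carbon would separate the nitrogen from the benzyl ring, while a benzyloxy group would keep the ring without the nitrogen and the carbonyl. A carboxylic acid or a longer alkoxy chain at the same carbon would add further single-place comparisons with compound 2.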